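A few compounds are considered here, and "the series" means these few. Any claim that something is new, unique, unknown or untested is made for them only; others in the source may bear on it.

Measured compounds:
Compound 1 `C[C@H](c1ccc(-c2cc(Cl)ccc2-c2nc(=O)o[nH]2)cc1)N(CC1CC1)c1nc2c(C(=O)O)cccc2o1`: 1300 ng.h/mL in an ADME assay on the whole organism (Macaca fascicularis) for pharmacokinetics, read by LC-MS, using cassette dosing, at a dose of 1 mg/kg by the oral route; a lower number here means less compound in the circulation, a higher number more compound in the circulation at the dose given
Compound 2 `CCCCN(c1nc2ccccc2o1)[C@H](C)c1ccc(-c2ccccc2-c2nnn[nH]2)cc1`: in this assay compound 2 gives 44.3 ng.h/mL

Of these two numbers, compound 1 stands highest, and its nearest neighbour, compound 2, lies well beyond the scatter below it. Compound 3 `C[C@H](c1ccc(-c2ccccc2-c2nc(=O)o[nH]2)cc1)N(CC1CC1)c1nc2c(C(=O)O)cccc2o1` differs from compound 1 by hydrogen in place of chloro on an aromatic carbon. For the measured compounds named here, no step between measured compounds covers this change, so there is no direct guide. The author expects a modest downward step, possibly within the scatter, from compound 1 to compound 3, estimated as a 1.6-fold lower number from compound 1 to compound 3 (0.21 log units; within the scatter). Compound 3 is therefore expected to give 800 ng.h/mL, within a range of 250 ng.h/mL to 2500 ng.h/mL.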

Compound 3, area under the concentration-time curve: 11600 ng.h/mL
Compound 3: the middle estimate sits 15-fold (1.16 log units) below what was measured; the whole stated range lies below it.
By their numbers in this assay, from the lowest: compound 2; then compound 1; then compound 3.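

For the compounds shown here, replacing the chloro, meta to a large group and para to a group of 6 heavy atoms, with hydrogen gives an 8.9-fold higher number from compound 1 to compound 3 (0.95 log units; beyond the scatter) in this assay and provides the first single-place comparison in this set. It shows that this one position can strongly change the read-out, and that removing the chloro here raises rather than lowers the number. Nothing available accounts for the size of this step. From the compounds shown here alone, whether fluoro, methyl or methoxy at this position would give a number nearer that of compound 1 or compound 3 remains open. Going by these compounds, it is also open whether the same change would have a similar effect in compound 2.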